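The compounds below may be only part of what the source reports. "The series", "measured", "known", "first", "only" and "open" are said of these compounds alone.

Of the compounds shown here, three in this small set have been tested so far, and a fourth is awaited. Compound 1 has the structure `N/C(=N\NC(=S)N1CCCCCC1)c1ccccn1`, compound 2 the structure `N/C(=N\NC(=S)N1CCSCC1)c1ccccn1`, and compound 3 the structure `N/C(=N\NC(=S)N1CCSCC1)c1ccc(F)cn1`. All three were measured in a functional assay on HeLa cells (Homo sapiens) for cytotoxicity, read by MTT assay, with a stated time of 72 h, tested at 3 uM; a higher number here means more inhibition of growth at the concentration tested, a lower number less inhibition of growth. In this assay compound 1 gives 36.6%, compound 2 gives 39.7%, and compound 3 gives 62.9%. The values of compound 1 and compound 2 lie within the usual scatter of each other, so nothing can be said about which of the two is stronger. The difference between the two cores of compound 1 and compound 2 is not broken down here.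

Compound 2 and compound 3 share a core and differ in one place: fluoro in place of hydrogen on an aromatic carbon This change brought a number 23.2 percentage points higher from compound 2 to compound 3 (beyond the scatter), a modest rise that lies beyond the scatter.

The unmeasured compound 4 has the structure `N/C(=N\NC(=S)N1CCCCCC1)c1ccc(F)cn1`. It stands to compound 1 exactly as compound 3 stands to compound 2: fluoro in place of hydrogen on an aromatic carbon The place of the change is described in the same words for both pairs, so this is the same change made on a different core. Going by the values given here, because the same change gave a number 23.2 percentage points higher from compound 2 to compound 3 (beyond the scatter), the expected step here is a number 21.4 percentage points higher from compound 1 to compound 4 (beyond the scatter), and compound 4 is estimated at 58%, likely between 44% and 72%, given that only one earlier example of this change is available.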

Compound 4, percent growth inhibition at one concentration: 65.1%
The estimate for compound 4 lay 7.1 percentage points below the measured number; measured number inside the range.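

In this assay, fluoro in place of hydrogen on an aromatic carbon gave a number 28.5 percentage points higher from compound 1 to compound 4 (beyond the scatter), so the rise seen on one core also appears on a second core. The two steps are alike in size, which means that, for this pair of cores, the effect of the change on growth inhibition carried over from one core to the other with no detectable loss or gain: the same change on two cores in this assay, a number 23.2 percentage points higher (beyond the scatter) from compound 2 to compound 3 and a number 28.5 percentage points higher (beyond the scatter) from compound 1 to compound 4, 5.3 percentage points apart, within the scatter of two such steps. Going by these compounds alone, this is still only two examples of one change, at one place on the ring and in one cell line at a single concentration, so it does not establish a general rule for other cores, and it does not explain why the fluoro compounds inhibit growth more.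

The compounds shown leave open whether another group at the same place, such as chloro, methyl, methoxy or an amine, would raise growth inhibition as fluoro does, and whether fluoro would do the same on another carbon of the ring. They also leave open whether the step would hold on a third core, or whether the same pattern would appear in other cell lines or across a range of concentrations.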